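This account rests on a few compounds, and the source may have more. Where it says the series, first, only, none or still open, it means among the compounds named here.

Compound 1 `O=C(COc1ccc(Oc2ccccc2)cc1)Cn1ncc2cc(NC(=O)Oc3ccccc3)ccc21`: 2100 nM in an assay on microsomes from brain for inhibition of Fatty-acid amide hydrolase 1 (Rattus norvegicus), read by fluorescence and HPLC, with a stated time of 45 min; on this read-out higher numbers stand for weaker inhibition and lower numbers for stronger inhibition
Compound 2 `CCNC(=O)Nc1ccc2c(cnn2CC(=O)COc2ccc(Oc3ccccc3)cc2)c1`: 1600 nM

Compound 2 stands level with compound 1 on these numbers: the step of a 1.3-fold lower number from compound 1 to compound 2 (0.12 log units; within the scatter) lies within the scatter. Compound 3 `O=C(COc1ccc(Oc2ccccc2)cc1)Cn1ncc2cc(NC(=O)NC3CCCCC3)ccc21` differs from compound 2 by cyclohexyl in place of ethyl on an amide-type nitrogen. Within the data shown here, no measured step exchanges one group for another on this nitrogen; the single step on record concerns the carbonyl carbon and stayed within the scatter. Nothing here points to a large move, so the change to compound 3 is expected to give only a 1.6-fold lower number from compound 2 to compound 3 (0.20 log units; within the scatter). Compound 3 is estimated at 1000 nM, with a range from 300 nM to 3500 nM.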

Compound 3, half-maximal inhibitory concentration: 840 nM
Compound 3: middle estimate off by 1.2-fold (0.08 log units), on the high side; measured number inside the range.
By their numbers in this assay, from the lowest: compounds 3, 2 and 1 (each within the scatter of the next, the first and the last beyond it).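

In this assay, cyclohexyl in place of ethyl on the amide-type nitrogen gives a 1.9-fold lower number from compound 2 to compound 3 (0.28 log units; within the scatter) and so shows that this nitrogen can carry a six-membered carbon ring with inhibition kept. Cyclohexylamino in place of phenoxy on the carbonyl carbon gives a 2.5-fold lower number from compound 1 to compound 3 (0.40 log units; beyond the scatter) and is the first step here to pass the scatter, though only modestly. No measured evidence accounts for either step.

Still open, on these data alone, is whether a flat phenyl ring or a longer chain such as hexyl on this nitrogen would do the same. A carboxylic acid or an amine on the cyclohexyl ring also remains untested in the compounds shown.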